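From bromo to iodo on a shared core

The source may report more compounds than this note shows. Statements on the series, on what has been measured and on what is new or still open speak of the compounds shown alone.

Measured so far:
compound 1 `CCc1ccccc1NC(=O)N[C@H](C)c1ccccc1` gives 101% in an ADME assay on the whole organism with Oryza sativa as the target, tested at 0.1 uM; a higher number here means a weaker effect of the compound at the concentration tested, a lower number a stronger effect
compound 2 `C[C@@H](NC(=O)Nc1ccccc1Br)c1ccccc1` gives 99% in this assay

Compound 2 stands alongside compound 1 with numbers close together: the step of a number 2 percentage points lower from compound 1 to compound 2 (within the scatter) is within the scatter, so the two cannot be told apart. Compound 3 `C[C@@H](NC(=O)Nc1ccccc1I)c1ccccc1` is not yet measured; it differs from compound 2 by iodo in place of bromo on an aromatic carbon. For the measured compounds named here, no measured step exchanges one halogen for another, so the only guide is that the single step seen, a number 2 percentage points lower from compound 1 to compound 2 (within the scatter), stayed within the scatter. For compound 3 the step of a number 1 percentage points lower from compound 2 to compound 3 (within the scatter) is therefore expected to stay within the scatter as well. Compound 3 is estimated at 98%, between 85% and 110%.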

Compound 3, a percentage reported as activity, at one concentration (the size of the read-out at that concentration, not a potency): 100%
The estimate for compound 3 lay 2 percentage points below the measured number; measured number inside the range.
By their numbers in this assay, from the lowest: compounds 2, 3 and 1 (each within the scatter of the next).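

In this assay iodo in place of bromo gives a number 1 percentage points higher from compound 2 to compound 3 (within the scatter) and iodo in place of ethyl gives a number 1 percentage points lower from compound 1 to compound 3 (within the scatter) so ethyl, bromo and iodo on this aromatic carbon, ortho to a large group, cannot be told apart. For the compounds shown here, this is the first exchange of one halogen for another at this place, and it leaves the number within the scatter. Nothing on hand offers an explanation for this result. The compounds shown leave open whether an amine or a carboxylic acid at this place would shift the number beyond the scatter. They also leave open whether any change elsewhere on the shared core would do so.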